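The compounds below may be only part of what the source reports. "The series", "measured", "known", "first", "only" and "open" are said of these compounds alone.

Measured in a functional assay on PC-3 cells (Homo sapiens) for inhibition, read by sulforhodamine B assay, with a stated time of 48 h; on this read-out lower numbers stand for stronger inhibition of growth and higher numbers for weaker inhibition of growth:
Compound 1 `CC1=CC[C@H](C(C)(C)NC(=S)N/N=C/c2ccc(O)cc2)CC1`: 600 nM.
Compound 2 `CC1=CC[C@H](C(C)(C)NC(=S)N/N=C/c2ccccc2O)CC1`: a limit of the assay, < 40 nM.
Compound 3 `CC1=CC[C@H](C(C)(C)NC(=S)N/N=C/c2ccccc2Cl)CC1`: 50 nM.

Compound 3 holds the lowest of the two numbers; the nearest number is that of compound 1, a 12-fold lower number from compound 1 to compound 3 (1.08 log units; beyond the scatter). The step to compound 4 `CC1=CC[C@H](C(C)(C)NC(=S)N/N=C/c2ccco2)CC1` is furan-2-yl in place of 2-chlorophenyl on a carbon with a double bond to nitrogen. The measured steps at this carbon, an at least 15-fold lower number from compound 1 to compound 2 (1.17 log units; beyond the scatter) and a 12-fold lower number from compound 1 to compound 3 (1.08 log units; beyond the scatter), both exchange one substituted phenyl for another; neither brings in a five-membered ring, and neither removes the aromatic substituent altogether. The step of an at least 1.2-fold higher number from compound 2 to compound 3 (0.09 log units; that floor lies within the scatter) rests on a floor within the scatter. Among the measured compounds shown here, no measured step therefore fixes the direction for compound 4; a move back toward the number of compound 1 is as plausible as no change. The expected step is a 5.0-fold higher number from compound 3 to compound 4 (0.70 log units; beyond the scatter). For compound 4 the estimate is 250 nM, from 70 nM to 1200 nM.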

Compound 4, concentration for 50% growth inhibition: 13500 nM
Beside the measured number, compound 4's estimate is 54-fold (1.73 log units) below it; the measured number lies above the stated range.
By their numbers in this assay, from the lowest: compound 3; then compound 1; then compound 4. At a limit, below all of these: compound 2.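

In this assay, furan-2-yl in place of 2-chlorophenyl on this carbon gives a 270-fold higher number from compound 3 to compound 4 (2.43 log units; beyond the scatter), a change of a different order from the exchanges among substituted phenyls. The 4-hydroxyphenyl group, the poorest of the phenyl groups with a measured number, still gives a lower number than furan-2-yl: a 23-fold higher number from compound 1 to compound 4 (1.35 log units; beyond the scatter). The step of an at least 330-fold higher number from compound 2 to compound 4 (2.52 log units; beyond the scatter) is only a floor, resting on a limit: the limit of < 40 nM in this assay, at which 1 of the 4 values shown sits.

From the compounds shown here alone, whether the rise follows the five-membered ring or its oxygen stays open. Thiophen-2-yl or unsubstituted phenyl on this carbon would separate the two.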